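A few compounds are considered here, and "the series" means these few. Any claim that something is new, unique, unknown or untested is made for them only; others in the source may bear on it.

In a functional assay on the whole organism (strain L.) for inhibition, with Echinochloa crus-galli as the target, with a stated time of 72 h, tested at 10 mg/L (a higher number here means more inhibition of growth at the concentration tested, a lower number less inhibition of growth), three compounds have been measured so far. Compound 1 `COc1cc(C)nc2n/c(=N/C(=O)c3c(-c4ccc(Cl)cc4Cl)noc3C)sn12` gives 30.9% in this assay. Compound 2 `COc1cc(SC)nc(NC(=S)NC(=O)c2c(-c3ccc(Cl)cc3Cl)noc2C)n1` gives 19.3% in this assay. Compound 3 `Cc1onc(-c2ccc(Cl)cc2Cl)c1C(=O)/N=c1/nc2nc(Cl)cc(C)n2s1` gives 25.8% in this assay. Compound 2 thus has the lowest of the three numbers; its nearest neighbour is compound 3, whose value lies within the usual scatter of it, while compound 1 lies further away, beyond the scatter. Among the measured compounds shown here, none of these three pairs differs in only one place, so no single-point step between measured compounds can be read from them.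

Compound 4 `COc1cc(C)nc(NC(=S)NC(=O)c2c(-c3ccc(Cl)cc3Cl)noc2C)n1` has not yet been measured. It follows from compound 2 by one change: methyl in place of methylsulfanyl on an aromatic carbon, a methyl in place of methylsulfanyl on an aromatic carbon. The rest of the molecule stays as it is in compound 2, including the shared core that all four compounds carry.

For the measured compounds named here, with no measured step of this kind available, the step from compound 2 to compound 4 in this assay is expected to be small, a number 2.7 percentage points higher from compound 2 to compound 4 (within the scatter), with no shift beyond the scatter in either direction. Compound 4 is therefore estimated to give 22% in this assay, within a range from 8% to 38%.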

Compound 4, percent growth inhibition at one concentration: 12.3%
For compound 4 the middle estimate is 9.7 percentage points above the measured one; the measured number falls inside the stated range.
By their numbers in this assay, from the lowest: compounds 4, 2, 3 and 1 (each within the scatter of the next, the first and the last beyond it).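

Among the compounds shown here, this is the first pair here that differs in only one place, so the methylsulfanyl group on the aromatic carbon next to the ring nitrogen can now be judged by itself. In this assay, methyl in place of methylsulfanyl gives a number 7 percentage points lower from compound 2 to compound 4 (within the scatter), so this single measurement cannot separate the effect of the swap from ordinary variation between repeats, even though the sulfur atom and one hydrogen-bond acceptor counted for the group are gone. No accompanying measurement bears on this result, and the two numbers alone offer no explanation for it.

The step describes one swap, at one position, on one scaffold, and a single pair cannot show how the growth inhibition responds to other groups placed there, such as an amine, an ethoxy group or a longer chain like ethylsulfanyl. From the compounds shown here alone, it also remains open whether methyl in place of methylsulfanyl would give a similar step on the differently built core of compound 1 and compound 3, since neither has a partner that differs from it in only one place.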